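Carboxy in place of amino: compound 3 to compound 4

The compounds below may be only part of what the source reports. "The series", "measured", "known", "first", "only" and "open" are said of these compounds alone.

Measured so far in a functional assay on MT4 cells (Homo sapiens) for cytotoxicity (on this read-out higher numbers stand for lower toxicity in this test and lower numbers for higher toxicity in this test), and each a limit of the assay:
- Compound 1 `Cc1cn(C2CC(N=[N+]=[N-])C(COC(=O)NCCCO)O2)c(=O)[nH]c1=O` gives > 50000 nM as a limit
- Compound 2 `Cc1cn(C2CC(N=[N+]=[N-])C(COC(=O)OCCCC(=O)OC(C)(C)C)O2)c(=O)[nH]c1=O` gives > 50000 nM as a limit
- Compound 3 `Cc1cn(C2CC(N=[N+]=[N-])C(COC(=O)OCCCN)O2)c(=O)[nH]c1=O` gives > 50000 nM as a limit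

Compound 3 has no number, only the limit of > 50000 nM in this assay, at which 3 of the 3 values shown sit, and so stands level with the other two as far as can be read. Compound 4 `Cc1cn(C2CC(N=[N+]=[N-])C(COC(=O)OCCCC(=O)O)O2)c(=O)[nH]c1=O` has carboxy in place of amino on a saturated chain carbon, three bonds along the chain from an oxygen next to a carbonyl group as its one difference. Among the compounds with values here, two measured steps bear on this: a step that the two limits leave unreadable from compound 1 to compound 3 and a step that the two limits leave unreadable from compound 2 to compound 3 give no usable size. No step beyond the scatter is therefore expected in this assay and no direction is favoured. The expected change is a step that the limit leaves unreadable from compound 3 to compound 4 in this reading. Compound 4 is estimated at 60000 nM with an expected range from 30000 nM to 120000 nM and will probably be reported only as a limit.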

Compound 4, half-maximal cytotoxic concentration: > 50000 nM
Compound 4: a limit, no number (the forecaster's own chance of this, stated with the estimate: 85%); the middle value lies beyond the limit too.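

No step can be read from compound 4 to compound 1, compound 2 or compound 3 in this assay, since each value is a limit: the limit of > 50000 nM in this assay, at which 4 of the 4 values shown sit.

The compounds shown leave open whether any of these changes alters the read-out at all.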